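Swapping Bromo for Methoxy on a Shared Core

This account rests on a few compounds, and the source may have more. Where it says the series, first, only, none or still open, it means among the compounds named here.

Three compounds built on one shared core differ only in the group carried on a six-membered aromatic ring of carbon only. Compound 1 `O=C1CSC(N2N=C(c3ccc(Cl)cc3)CC2c2cccc3ccccc23)=N1` carries chloro, and in a functional assay on BGC-823 cells (Homo sapiens) for inhibition, read by CCK-8 assay, with a stated time of 48 h (a lower number here means a stronger inhibitor, a higher number a weaker inhibitor), compound 1 gives 16400 nM. Compound 2 `O=C1CSC(N2N=C(c3ccc(F)cc3)CC2c2cccc3ccccc23)=N1` carries fluoro, and in this assay compound 2 gives 19300 nM. Compound 3 `O=C1CSC(N2N=C(c3ccc(Br)cc3)CC2c2cccc3ccccc23)=N1` carries bromo, and in this assay compound 3 gives 14600 nM. On these numbers compound 3 has the lowest value of the three, yet the steps of a 1.1-fold lower number from compound 1 to compound 3 (0.05 log units; within the scatter) and a 1.3-fold lower number from compound 2 to compound 3 (0.12 log units; within the scatter) both lie within the scatter, as does a 1.2-fold higher number from compound 1 to compound 2 (0.07 log units; within the scatter), so the three halogens cannot be told apart here.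

Compound 4 `COc1ccc(C2=NN(C3=NC(=O)CS3)C(c3cccc4ccccc34)C2)cc1` is the next member of the set: methoxy in place of bromo on an aromatic carbon. For the measured compounds named here, no measured step involves methoxy, so the halogen steps, all within the scatter, are the only guide. They show that this position accepts different groups without a change beyond the scatter, although methoxy adds a hydrogen-bond acceptor that none of the halogens carries, which widens the uncertainty. The step of a 1.2-fold higher number from compound 3 to compound 4 (0.09 log units; within the scatter) is therefore expected to be small. Compound 4 is expected to give 18000 nM in this assay, within a range from 8000 nM to 40000 nM.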

Compound 4, half-maximal inhibitory concentration: 8210 nM
Beside the measured number, compound 4's estimate is 2.2-fold (0.34 log units) above it; low and high end bracket the measured number.
By their numbers in this assay, from the lowest: compounds 4, 3, 1 and 2 (each within the scatter of the next, the first and the last beyond it).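

Among the halogens, no swap at this place on the aromatic ring moved the number beyond the scatter, but methoxy gives the first step that does so: in this assay there is a 2.4-fold lower number from compound 2 to compound 4 (0.37 log units; beyond the scatter), so the position is not wholly indifferent to the group it carries. This step is modest and rests on one pair, as the comparisons with the other two halogens stay within the scatter, at a 1.8-fold lower number from compound 3 to compound 4 (0.25 log units; within the scatter) and a 2.0-fold lower number from compound 1 to compound 4 (0.30 log units; within the scatter), and compound 4 therefore cannot be set apart from compound 1 or compound 3. No supporting measurement is available to explain the difference between methoxy and fluoro.

Going by these compounds, what remains open is whether other groups at this place, such as a hydroxyl, an amine or the longer ethoxy, would extend the separation from fluoro or leave the number within the scatter of these four compounds. It is also open whether the step from fluoro to methoxy would hold on the shared core in other cell types, as only this assay is shown here.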